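Moving Two Fluorines on the Amide Aryl Group

A few compounds are considered here, and "the series" means these few. Any claim that something is new, unique, unknown or untested is made for them only; others in the source may bear on it.

Measured so far:
Compound 1, `CC(C)n1ncc2c(C(=O)Nc3ccc(F)c(F)c3)cc(-c3cccs3)nc21`, gives > 200000 nM in an ADME assay on LLC-MK2 cells (Macaca mulatta) for cytotoxicity, read by spectrophotometry and crystal violet staining, with a stated time of 4 days; on this read-out higher numbers stand for lower toxicity in this test and lower numbers for higher toxicity in this test.
Compound 2, `CC(C)n1ncc2c(C(=O)Nc3ccc(F)c(S(N)(=O)=O)c3)cc(-c3cccs3)nc21`, gives 50000 nM in this assay.

Compound 1 is the starting point. In this assay compound 1 returns only a limit, > 200000 nM, not a number; this is the limit of > 200000 nM in this assay, at which 1 of the 2 values shown sits. Among the compounds with values here, the one measured step, an at least 4.0-fold lower number from compound 1 to compound 2 (0.60 log units; beyond the scatter), exchanges a fluorine for a sulfamoyl group and reaches a number for compound 2, whereas compound 1 sits at the limit, so the true size of that step is unknown.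

Compound 3, `CC(C)n1ncc2c(C(=O)Nc3cccc(F)c3F)cc(-c3cccs3)nc21`, is not yet measured. Its difference from compound 1 is 2,3-difluorophenyl in place of 3,4-difluorophenyl on an amide-type nitrogen. The measured step rests on a different change, a sulfamoyl entering, and nothing measured here shows what rearranging two fluorines does; both fluorines stay and no donor or acceptor enters. Compound 3 is therefore expected to show no step beyond the scatter, a number no higher from compound 1 to compound 3 (the limit leaves the size open). Compound 3 is estimated at 200000 nM, in the range 100000 nM to 400000 nM, and it may well return only a limit again.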

Compound 3, half-maximal cytotoxic concentration: 75000 nM
Compound 3: middle estimate off by 2.7-fold (0.43 log units), on the high side; measured number below the stated range.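

Simply moving the fluorines around the ring is enough to change the result: in this assay, 2,3-difluorophenyl in place of 3,4-difluorophenyl on the amide-type nitrogen gives an at least 2.6-fold lower number from compound 1 to compound 3 (0.42 log units; beyond the scatter), and a lower number here stands for higher toxicity in this test. The group that leaves and the group that enters have the same atoms, the same ring and the same counted hydrogen-bond donors and acceptors, so at this position a new group such as sulfamoyl is not needed to produce a step beyond the scatter. Going by these compounds, the full size of this step remains unknown because compound 1 returns only a limit and not a number: the limit of > 200000 nM in this assay, at which 1 of the 3 values shown sits.

The values shown do not explain why this rearrangement lowers the number, and two compounds with the same atoms cannot separate the role of one fluorine from that of the other. On these data alone, it also remains open how this position would respond to a plain phenyl ring, a methoxy group, an amine or a carboxylic acid on the ring in place of the fluorines.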